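Adding a Methyl Near the Amine: Two Cores Compared

This account rests on a few compounds, and the source may have more. Where it says the series, first, only, none or still open, it means among the compounds named here.

Measured so far in a functional assay (aorta) with Rattus norvegicus as the target; a higher number here means that more compound is needed for the effect, a lower number that less compound is needed:
compound 1 `CC(C)NC1=NS(=O)(=O)c2cc(F)ccc2N1` gives 43.1 uM
compound 2 `CCC(C)NC1=NS(=O)(=O)c2cc(F)ccc2N1` gives 39.2 uM
compound 3 `CC(C)(C)NC1=NS(=O)(=O)c2cc(Cl)ccc2N1` gives 1.4 uM

The three measured compounds split into two groups by core. Compound 1 and compound 2 share one core and differ in a single place: methyl in place of hydrogen on a saturated chain carbon, two bonds along the chain from an amine nitrogen. That change made a 1.1-fold lower number from compound 1 to compound 2 (0.04 log units; within the scatter), so the two numbers cannot be told apart. Compound 3 carries a different core; the difference between the two cores is not broken down here. What stands out is that compound 3 needs far less compound for the half-maximal effect than either compound 1 or compound 2, and both of those gaps lie beyond the scatter.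

Compound 4 `CCC(C)(C)NC1=NS(=O)(=O)c2cc(Cl)ccc2N1` has not yet been measured. It differs from compound 3 by methyl in place of hydrogen on a saturated chain carbon, two bonds along the chain from an amine nitrogen. This is the same change, at the same place, that turns compound 1 into compound 2, so among the compounds shown it occurs twice in all. Because a 1.1-fold lower number from compound 1 to compound 2 (0.04 log units; within the scatter) stayed within the scatter, the expected step on the core of compound 3 is also small: in this assay the estimated step is a 1.1-fold lower number from compound 3 to compound 4 (0.03 log units; within the scatter). That rests on a single earlier example on a different core, so the range must stay wide. Compound 4 is therefore expected to give about 1.3 uM, most likely between 0.5 uM and 4 uM.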

Compound 4, concentration for half-maximal effect: 0.29 uM
Compound 4: middle estimate off by 4.5-fold (0.65 log units), on the high side; the whole stated range lies above it.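

In this assay, the change from tert-butyl to 1,1-dimethylpropyl gave a 4.8-fold lower number from compound 3 to compound 4 (0.68 log units; beyond the scatter) and so made a real difference on this core. The same change therefore cannot be assumed to have the same size on a different core in this series, as the two measured cases show: the same change on two cores in this assay, a 1.1-fold lower number (0.04 log units; within the scatter) from compound 1 to compound 2 and a 4.8-fold lower number (0.68 log units; beyond the scatter) from compound 3 to compound 4, 4.4-fold (0.64 log units) apart, beyond the scatter of two such steps. Within the data shown here, this does not explain why the two cases part ways, and with only two examples it gives no rule for what the change would do on a third core, while the pairs also differ in more than one place, so the core alone cannot be singled out as what matters.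

The compounds shown leave open whether a longer chain in this same place, such as a 1,1-dimethylbutyl group, would lower the number further or whether the gain stops at 1,1-dimethylpropyl. They also leave open how a ring or a hydroxyl group on that chain would compare, and whether the result depends on the chlorine on the core, a question that would need the same change made on cores that differ only in that one atom.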